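Chloro addition on the aniline ring across two sulfonyl cores

A few compounds are considered here, and "the series" means these few. Any claim that something is new, unique, unknown or untested is made for them only; others in the source may bear on it.

Compound 1 `Cc1ccc(S(=O)(=O)N/C(=N\O)Nc2ccc(Cl)cc2)cc1` gives 58 ug/mL in a functional assay on COLO 205 cells (Homo sapiens) for cytotoxicity; on this read-out lower numbers stand for stronger inhibition and higher numbers for weaker inhibition. Compound 2 `Cc1c(S(=O)(=O)N/C(=N\O)Nc2ccc(Cl)cc2)sc2ccc(Cl)cc12` carries a different sulfonyl core and gives 60 ug/mL in this assay; the two values lie within the scatter of each other, and the difference between the two cores is not broken down here. Compound 3 `Cc1ccc(S(=O)(=O)N/C(=N\O)Nc2ccc(Cl)c(Cl)c2)cc1` differs from compound 1 by chloro in place of hydrogen on an aromatic carbon. In this assay compound 3 gives 10 ug/mL, a step of a 5.8-fold lower number from compound 1 to compound 3 (0.76 log units; beyond the scatter).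

Compound 4 `Cc1c(S(=O)(=O)N/C(=N\O)Nc2ccc(Cl)c(Cl)c2)sc2ccc(Cl)cc12` is not yet measured. It differs from compound 2 by chloro in place of hydrogen on an aromatic carbon, the same change as that from compound 1 to compound 3, made on the same place. For the measured compounds named here, since compound 1 and compound 2 sit within the scatter of each other in this assay, the one measured step, a 5.8-fold lower number from compound 1 to compound 3 (0.76 log units; beyond the scatter), is the only guide, and a step of about that size is expected from compound 2 to compound 4, a 5.0-fold lower number from compound 2 to compound 4 (0.70 log units; beyond the scatter). Compound 4 is therefore estimated at 12 ug/mL in this assay, with a likely range from 5 ug/mL to 30 ug/mL.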

Compound 4, half-maximal inhibitory concentration: > 300 ug/mL
Compound 4: a limit, no number (the forecaster's own chance of this, stated with the estimate: 5%); at least 25-fold (1.39 log units) between middle value and limit.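

In this assay compound 4 gives > 300 ug/mL, which is a limit of the assay and not a number. The change from 4-chlorophenyl to 3,4-dichlorophenyl, read on the second core as an at least 5.0-fold higher number from compound 2 to compound 4 (0.69 log units; beyond the scatter), runs opposite to the step on the core of compound 1, so within these two pairs the effect of this chloro does not carry from one core to the other: the same change on two cores in this assay, a 5.8-fold lower number (0.76 log units; beyond the scatter) from compound 1 to compound 3 and an at least 5.0-fold higher number (0.69 log units; beyond the scatter) from compound 2 to compound 4, at least 29-fold (1.46 log units) apart, beyond the scatter of two such steps This rests on a single pair per core; with only a limit for compound 4, the true size of the step on the core of compound 2 stays unknown, the reason for the reversal is not shown, and no rule for other cores follows.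

Still open, from the compounds shown here alone, is whether the reversal is particular to chloro, which a fluoro, methyl or methoxy group at the same place on the core of compound 2 could test. Also open, going by these compounds, is whether an amine or a carboxylic acid at that place would follow either core.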